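Swapping Methoxy for Phenyl in a Cell Toxicity Test

The source may report more compounds than this note shows. Statements on the series, on what has been measured and on what is new or still open speak of the compounds shown alone.

Compound 1 `C=C[C@@](C)(/C=C/c1ccc(OC)cc1)CCC=C(C)C` was tested in an ADME assay on HEK293 cells (Homo sapiens) for cytotoxicity, with a stated time of 72 h; a lower number here means that less compound is needed, a higher number that more compound is needed for the effect. In this assay compound 1 gives only a limit, > 36600 nM, so no exact number is known for it. Compound 2 `CC(C)=CCC[C@](C)(/C=C/c1ccc(O)cc1)/C=C/c1ccc(C#N)cc1` shows the same kind of outcome: in this assay compound 2 also reaches only a limit, > 36600 nM. Among the compounds with values here, this is the limit of > 36600 nM in this assay, at which 2 of the 2 values shown sit, and compound 1 therefore stands at the limit together with the only other measured compound.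

Compound 3 `C=C[C@@](C)(/C=C/c1ccc(-c2ccccc2)cc1)CCC=C(C)C` has not yet been measured. It differs from compound 1 in one place: phenyl in place of methoxy on an aromatic carbon. Within the data shown here, no pair of measured compounds differs in this way, so the step has no direct precedent among the values shown. Because both known values sit at the limit (the limit of > 36600 nM in this assay, at which 2 of the 2 values shown sit), the step that is expected here, an at least 1.2-fold lower number from compound 1 to compound 3 (0.08 log units; that floor lies within the scatter), should stay within the usual scatter of this assay. Compound 3 is estimated at 30000 nM, with a likely range from 10000 nM to 80000 nM.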

Compound 3, half-maximal effective concentration: > 36600 nM
Compound 3 gave a limit, no number; the forecaster's own chance of this, stated with the estimate: 60%; middle value at least 1.2-fold (0.08 log units) from the limit.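

Compound 1 and compound 3 both give only a limit in this assay, so no step can be read for the swap of methoxy for phenyl: the limit of > 36600 nM in this assay, at which 3 of the 3 values shown sit. The compounds shown leave open at what concentration, if any, each would reach the half-maximal effect on these cells.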